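Fluoro to chloro exchange on two related cores

The source may report more compounds than this note shows. Statements on the series, on what has been measured and on what is new or still open speak of the compounds shown alone.

Compound 1 `COc1ccc2[nH]c(-c3cn(-c4ccccc4)nc3-c3ccc(F)cc3)nc2c1` and compound 2 `COc1ccc2[nH]c(-c3cn(-c4ccccc4)nc3-c3ccc(Cl)cc3)nc2c1` share one core; compound 3 `COc1ccc(-c2nn(-c3ccccc3)cc2-c2nc3cc(F)ccc3[nH]2)cc1` and compound 4 `COc1ccc(-c2nn(-c3ccccc3)cc2-c2nc3cc(Cl)ccc3[nH]2)cc1` share another, built from the same atoms joined differently. How the two cores differ is not broken down here. In a functional assay on A549 cells (Homo sapiens) for antiproliferative activity, read by MTT assay, with a stated time of 48 h (on this read-out lower numbers stand for stronger inhibition and higher numbers for weaker inhibition), compound 1 gives 1960 nM and compound 2 gives 2420 nM; the change chloro in place of fluoro on an aromatic carbon made a 1.2-fold higher number from compound 1 to compound 2 (0.09 log units; within the scatter). Compound 3 gives 1980 nM in this assay. The change chloro in place of fluoro on an aromatic carbon is the same kind of change, but the place differs: in compound 1 the carbon is para to a large group, whereas in compound 3 it lies in a six-membered aromatic ring of carbon only that is part of a fused or bridged system of two rings, meta to a fused ring and para to a fused ring. The expected step is a 1.2-fold higher number from compound 3 to compound 4 (0.08 log units; within the scatter), resting on the earlier swap because a 1.2-fold higher number from compound 1 to compound 2 (0.09 log units; within the scatter) lay within the scatter. Compound 4 is estimated at 2400 nM in this assay, between 1200 nM and 4800 nM.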

Compound 4, half-maximal inhibitory concentration: 3130 nM
For compound 4 the middle estimate is 1.3-fold (0.12 log units) below the measured one; the range from low to high includes it.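

In this assay, chloro in place of fluoro on the aromatic carbon of the second core gives a 1.6-fold higher number from compound 3 to compound 4 (0.20 log units; within the scatter), and this step does not stand apart from the earlier one: the same change on two cores in this assay, a 1.2-fold higher number (0.09 log units; within the scatter) from compound 1 to compound 2 and a 1.6-fold higher number (0.20 log units; within the scatter) from compound 3 to compound 4, 1.3-fold (0.11 log units) apart, within the scatter of two such steps. On these two cores, then, the change carries over without a detectable difference, and neither step leaves the scatter. Within the data shown here, this does not show that the swap would behave alike on other cores, and with only two pairs and such small steps it cannot separate any influence of the core or the place from noise.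

Still open, on these data alone, is whether an amine, a nitrile or a carboxylic acid on these same carbons would move the number beyond the scatter.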